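Swapping Trifluoromethyl for Methoxy: Oral Exposure Outlook

The compounds below may be only part of what the source reports. "The series", "measured", "known", "first", "only" and "open" are said of these compounds alone.

Compound 1 `COc1cc(N2C(=O)C3(CCC3)N(c3ccc(OC4CCN(C)CC4)nc3)C2=S)cnc1C#N` in an ADME assay on the whole organism (Mus musculus, strain CD1) for pharmacokinetics, at a dose of 10 mg/kg by the oral route (a lower number here means less compound in the circulation, a higher number more compound in the circulation at the dose given), gives 1320 nM.
Compound 2 `CN1CCC(Oc2ccc(N3C(=S)N(c4cnc(C#N)c(C(F)(F)F)c4)C(=O)C34CCC4)cc2)CC1` in this assay gives 980 nM.
Compound 3 `CN1CCC(Oc2ccc(N3C(=S)N(c4cnc(C#N)c(C(F)(F)F)c4)C(=O)C34CCC4)cn2)CC1` in this assay gives 1300 nM.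

All three measured numbers lie within the scatter of one another in this assay, so none of the compounds can be set apart from the others on this read-out. Compound 3 and compound 1 differ in a single place: methoxy in place of trifluoromethyl on an aromatic carbon. That change made a 1.0-fold higher number from compound 3 to compound 1 (0.01 log units; within the scatter). Compound 2 and compound 3 both carry the trifluoromethyl group, but the difference between their two cores is not broken down here.

Compound 4 `COc1cc(N2C(=O)C3(CCC3)N(c3ccc(OC4CCN(C)CC4)cc3)C2=S)cnc1C#N` has not yet been measured. It relates to compound 2 exactly as compound 1 relates to compound 3: methoxy in place of trifluoromethyl on an aromatic carbon, the same change at the same place. Because the step of a 1.0-fold higher number from compound 3 to compound 1 (0.01 log units; within the scatter) stayed within the scatter, a step of similar size is expected here, a 1.0-fold higher number from compound 2 to compound 4 (0.01 log units; within the scatter). On that basis compound 4 is estimated to reach 1000 nM in this assay, with a likely range from 450 nM to 2200 nM.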

Compound 4, maximal plasma concentration: 2800 nM
Beside the measured number, compound 4's estimate is 2.8-fold (0.45 log units) below it, and the stated range ends below it.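

Methoxy in place of trifluoromethyl gave a 2.9-fold higher number from compound 2 to compound 4 (0.46 log units; beyond the scatter) in this assay, meaning more compound in the circulation at the same oral dose. On the core of compound 1, the same change stayed within the scatter, so the size of its effect in this series cannot simply be copied from one core to another: the same change on two cores in this assay, a 1.0-fold higher number (0.01 log units; within the scatter) from compound 3 to compound 1 and a 2.9-fold higher number (0.46 log units; beyond the scatter) from compound 2 to compound 4, 2.8-fold (0.45 log units) apart, beyond the scatter of two such steps These two pairs show that the outcome of this change depends on the core it sits on, but they do not show which feature of the core is responsible, or which of the two results a further core would follow.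

On these data alone, it remains open whether other groups at this place, such as an amine, a fluorine atom or a longer ether chain, would also give different results on the two cores. Also open, as far as these compounds go, is whether the gap between the two cores would hold at another oral dose.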